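A few compounds are considered here, and "the series" means these few. Any claim that something is new, unique, unknown or untested is made for them only; others in the source may bear on it.

Compound 1 `CC(=O)Oc1ccc2oc(/C=C/[S+](C)[O-])cc(=O)c2c1`: 4100 nM
Compound 2 `CCCCCOc1ccc2oc(/C=C/[S+](C)[O-])cc(=O)c2c1`: 1600 nM
Compound 3 `CC(C)CC(=O)Oc1ccc2oc(/C=C/[S+](C)[O-])cc(=O)c2c1`: 2300 nM

These numbers come from a functional assay on A549 cells (Homo sapiens) for cytotoxicity, with a stated time of 48 h; on this read-out higher numbers stand for weaker inhibition and lower numbers for stronger inhibition. Compound 3, at 2300 nM, cannot be ranked against the other two, since both of its gaps lie within the scatter. The next compound, compound 4 `CCCCC(=O)Oc1ccc2oc(/C=C/[S+](C)[O-])cc(=O)c2c1`, has the same atoms as compound 3, joined differently: propyl in place of isopropyl on a saturated chain carbon bound to a carbonyl carbon. In words, propyl takes the place of isopropyl on a saturated chain carbon bound to a carbonyl carbon.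

For the measured compounds named here, no measured step makes this exact swap. The closest evidence comes from the same place on compound 3, where isopropyl in place of hydrogen gave only a 1.8-fold lower number from compound 1 to compound 3 (0.25 log units; within the scatter). Exchanging the whole group on oxygen gave just a 1.4-fold higher number from compound 2 to compound 3 (0.16 log units; within the scatter). Only a 2.6-fold lower number from compound 1 to compound 2 (0.41 log units; beyond the scatter) passes the scatter, and it is modest. No change beyond the scatter, in either direction, is therefore expected for this rearrangement. The expected step is a 1.0-fold lower number from compound 3 to compound 4 (0.02 log units; within the scatter). The estimate for compound 4 is 2200 nM, with an expected range of 1200 nM to 3900 nM.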

Compound 4, half-maximal inhibitory concentration: 2400 nM
For compound 4 the middle estimate is 1.1-fold (0.04 log units) below the measured one, and the stated range covers the measured number.
By their numbers in this assay, from the lowest: compounds 2, 3, 4 and 1 (each within the scatter of the next, the first and the last beyond it).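

Turning the branched isopropyl into the straight propyl on the saturated chain carbon bound to the carbonyl carbon produces no readable change in this assay, with a 1.0-fold higher number from compound 3 to compound 4 (0.02 log units; within the scatter), so at this place branching makes no visible difference among these chains. The butylcarbonyl group on the oxygen also cannot be told apart from pentyl, with a 1.5-fold higher number from compound 2 to compound 4 (0.18 log units; within the scatter), and propyl in place of hydrogen on that carbon stays within the scatter as well, with a 1.7-fold lower number from compound 1 to compound 4 (0.23 log units; within the scatter). No measurement is at hand that could explain these results.

Still open, going by these compounds, is whether a much longer chain, a phenyl group or an amine at this carbon would give a step beyond the scatter. Also open, on these data alone, is how a carboxylic acid at the end of this chain would read.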